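Amine substituent variation on the quinazoline-free shared core

The source may report more compounds than this note shows. Statements on the series, on what has been measured and on what is new or still open speak of the compounds shown alone.

Values in a functional assay for antagonist activity at transient receptor potential cation channel subfamily V member 1 (Homo sapiens); a higher number here means a weaker inhibitor, a lower number a stronger inhibitor:
compound 1 `O=C(O)CCc1nc(Nc2ccc(C(F)(F)F)cc2)c2ccc(-c3ncccc3C(F)(F)F)cc2n1`: 1630 nM
compound 2 `CC(C)NCc1nc(Nc2ccc(C(F)(F)F)cc2)c2ccc(-c3ncccc3C(F)(F)F)cc2n1`: 35 nM

Compound 2 holds the lowest of the two numbers; its nearest neighbour is compound 1, separated by a 47-fold lower number from compound 1 to compound 2 (1.67 log units; beyond the scatter), a change at the saturated chain carbon bound to an aromatic carbon.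

Compound 3 `FC(F)(F)c1ccc(Nc2nc(CNC3CCCCC3)nc3cc(-c4ncccc4C(F)(F)F)ccc23)cc1` is not yet measured. It differs from compound 2 by cyclohexyl in place of isopropyl on an amine nitrogen. For the measured compounds named here, the one measured step, a 47-fold lower number from compound 1 to compound 2 (1.67 log units; beyond the scatter), concerns the exchange of carboxymethyl for isopropylamino and says nothing about what the amine carries; no measured pair alters the group on the amine nitrogen. With nothing that bears on it, no step beyond the scatter is expected: a 1.2-fold lower number from compound 2 to compound 3 (0.07 log units; within the scatter). For compound 3 in this assay the estimate is 30 nM, with a range from 10 nM to 100 nM.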

Compound 3, half-maximal inhibitory concentration: 6 nM
For compound 3 the middle estimate is 5.0-fold (0.70 log units) above the measured one; measured number outside the range, below it.
By their numbers in this assay, from the lowest: compound 3; then compound 2; then compound 1.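

In this assay, for the compounds shown here, the group carried by the amine nitrogen is not neutral: cyclohexyl in place of isopropyl gives a 5.8-fold lower number from compound 2 to compound 3 (0.77 log units; beyond the scatter), the first measured change at this place, and it lies beyond the scatter. Taken with the exchange on the saturated chain carbon, cyclohexylamino in place of carboxymethyl gives a 270-fold lower number from compound 1 to compound 3 (2.43 log units; beyond the scatter), the widest step among the three compounds shown. No measurement bears on the reason for either step.

The compounds shown leave open whether the lower number goes with the ring or with the carbon count: cyclopentyl, or an open chain such as n-hexyl, on the same amine nitrogen would separate the two. Also open, on these data alone, is what a second group on that nitrogen, such as methyl, would do in this assay to this series.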